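The compounds below may be only part of what the source reports. "The series", "measured", "known", "first", "only" and "open" are said of these compounds alone.

Compound 1 `O=C(CN1CCN(c2nnc(Cc3ccncc3)c3ccccc23)CC1)Nc1cccc(F)c1`: 4.4 nM
Compound 2 `O=C(CN1CCN(c2nnc(Cc3ccccc3)c3ccccc23)CC1)Nc1cc(C(F)(F)F)ccc1Cl`: 19500 nM

In a functional assay on MDA-MB-231 cells (Homo sapiens) for cytotoxicity, read by MTT assay, with a stated time of 72 h (a lower number here means a stronger inhibitor, a higher number a weaker inhibitor), compound 2 gives 19500 nM. That is the higher of the two numbers, so it is the weaker inhibitor of the pair, and the gap to compound 1 at 4.4 nM lies far beyond the scatter.

The next compound to examine is compound 3 `O=C(CN1CCN(c2nnc(Cc3ccccc3)c3ccccc23)CC1)Nc1cccc(F)c1`. It has 3-fluorophenyl in place of the 2-chloro-5-(trifluoromethyl)phenyl of compound 2 on an amide-type nitrogen (3-fluorophenyl in place of 2-chloro-5-(trifluoromethyl)phenyl on an amide-type nitrogen). Going by the values given here, no measured pair yet shows what a change at this place does on its own, so any forecast here is uncertain. One clue is available: compound 1, at 4.4 nM, also carries 3-fluorophenyl on its amide-type nitrogen. A move towards a lower number therefore seems likely, although compound 3 may not reach the value of compound 1. The expected change is a 65-fold lower number from compound 2 to compound 3 (1.81 log units; beyond the scatter), which would be beyond the scatter. For compound 3 the estimated value in this assay is 300 nM, with an expected range from 10 nM to 10000 nM.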

Compound 3, half-maximal inhibitory concentration: 3730 nM
For compound 3 the middle estimate is 12-fold (1.09 log units) below the measured one, within the range that was stated.
By their numbers in this assay, from the lowest: compound 1; then compound 3; then compound 2.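

In this assay, the new compound separates the two places in which compound 1 and compound 2 differ, so each change can now be read on its own. On the amide-type nitrogen, 3-fluorophenyl in place of 2-chloro-5-(trifluoromethyl)phenyl gives a 5.2-fold lower number from compound 2 to compound 3 (0.72 log units; beyond the scatter), a modest step, whereas phenyl in place of pyridin-4-yl on the saturated chain carbon gives an 850-fold higher number from compound 1 to compound 3 (2.93 log units; beyond the scatter), a large step in the opposite direction, showing that in these compounds the swap between pyridin-4-yl and phenyl moves the number much further than the change on the amide-type nitrogen. No measurement at hand explains why either change has the effect it does.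

The compounds shown leave open whether this large step is specific to pyridin-4-yl, which a pyridin-3-yl or pyridin-2-yl group on the same chain carbon would help to test. They also leave open whether pyridin-4-yl gives a step of similar size when 2-chloro-5-(trifluoromethyl)phenyl sits on the amide-type nitrogen.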